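Swapping Fluoro for Cyano on an Aromatic Ring

This account rests on a few compounds, and the source may have more. Where it says the series, first, only, none or still open, it means among the compounds named here.

Compound 1 `Cc1c[nH]cc1C(=O)O` is a small acid that, in an assay on cells for inhibition of Palmitoleoyl-protein carboxylesterase NOTUM variant C330S (Homo sapiens), read by fluorescence, with a stated time of 40 min (on this read-out lower numbers stand for stronger inhibition and higher numbers for weaker inhibition), gives 100000 nM. For the measured compounds named here, compound 2 `Cc1cc(C(=O)O)c(C)n1-c1cccc(F)c1` keeps the acid on a larger frame that carries an aromatic ring bearing fluorine; in this assay compound 2 gives 1500 nM, the lowest of the two numbers so far, and its gap to compound 1 lies well beyond the usual scatter. Compound 3 `Cc1cc(C(=O)O)c(C)n1-c1cccc(C#N)c1` is still to be measured. It differs from compound 2 in one place: cyano in place of fluoro on an aromatic carbon. Going by the values given here, no measured pair shows what this change does on its own. Such a change is expected to move the number in this assay only a little, if at all, so a small step to the lower side, within the scatter, is expected: a 1.5-fold lower number from compound 2 to compound 3 (0.18 log units; within the scatter). Compound 3 is therefore estimated at 1000 nM, with a range from 300 nM to 4000 nM.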

Compound 3, half-maximal inhibitory concentration: 3100 nM
Compound 3: middle estimate off by 3.1-fold (0.49 log units), on the low side; the range from low to high includes it.
By their numbers in this assay, from the lowest: compound 2; then compound 3; then compound 1.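

Placing cyano instead of fluoro on this aromatic carbon, meta to a large group, is not a neutral exchange in this assay but gives a 2.1-fold higher number from compound 2 to compound 3 (0.32 log units; beyond the scatter) as a modest step. Since a higher number stands for weaker inhibition, this position responds to the group it carries, and of the two groups compared, fluoro gives the stronger inhibition. Cyano has more heavy atoms than fluoro and counts a hydrogen-bond acceptor, but no measurement here says whether either feature lies behind the shift.

Still open, from the compounds shown here alone, is how this position would respond to a different group, such as a chlorine, a methoxy group or an amine, or to plain hydrogen, which would show whether fluoro itself adds anything. Also open, going by these compounds, is whether the same swap would have a similar effect elsewhere on this aromatic ring.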